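The source may report more compounds than this note shows. Statements on the series, on what has been measured and on what is new or still open speak of the compounds shown alone.

Measured in an ADME assay on HEK293 cells (Homo sapiens) for cytotoxicity, read by resazurin assay, with a stated time of 48 h; on this read-out lower numbers stand for higher toxicity in this test and higher numbers for lower toxicity in this test:
compound 1 `O=S(=O)(Nc1ccc(-c2nc3ccccc3o2)cc1)c1ccccc1F` gives > 100000 nM, a limit of the assay.
compound 2 `COc1ccccc1S(=O)(=O)Nc1ccc2oc(-c3ccccc3)nc2c1` gives 41000 nM.
compound 3 `O=S(=O)(Nc1ccc2oc(-c3ccccc3)nc2c1)c1ccc(Cl)s1` gives > 100000 nM, a limit of the assay.

Compound 1 thus stands at the limit of > 100000 nM in this assay, at which 2 of the 3 values shown sit, and no number is known for it. Compound 4 `O=S(=O)(Nc1ccc(-c2nc3ccccc3o2)cc1)c1ccc(Cl)cc1` differs from compound 1 by 4-chlorophenyl in place of 2-fluorophenyl on a sulfonyl sulfur. For the measured compounds named here, only one measured step alters the group on the sulfonyl sulfur: an at least 2.4-fold higher number from compound 2 to compound 3 (0.38 log units; beyond the scatter), which moved from a number up to the limit. Neither that step nor any other value involves 4-chlorophenyl or 2-fluorophenyl, so no direction can be read from them. Compound 1 already sits at the limit. Compound 4 is therefore expected to stay there, with an estimated step of a number no higher from compound 1 to compound 4 (the limit leaves the size open) of none beyond the scatter. Compound 4 is estimated at 100000 nM, range 40000 nM to 300000 nM, most likely reported as a limit again.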

Compound 4, half-maximal cytotoxic concentration: > 100000 nM
Compound 4: a limit, no number; the forecaster's own chance of this, stated with the estimate: 75%; the middle value lies on the limit itself.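

Compound 1 and compound 4 both give a limit rather than a number in this assay, so no step can be read between them: the limit of > 100000 nM in this assay, at which 3 of the 4 values shown sit.

The compounds shown leave open how 4-chlorophenyl and 2-fluorophenyl on a sulfonyl sulfur compare in this assay.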